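Swapping the pendant aryl ring in an imidazoline series

The source may report more compounds than this note shows. Statements on the series, on what has been measured and on what is new or still open speak of the compounds shown alone.

Compound 1 `Cc1ccc(-c2ccccc2OC(C)C2=NCCN2)cc1`: 398 nM
Compound 2 `Cc1ccccc1-c1ccccc1OC(C)C1=NCCN1`: 832 nM

Of the compounds shown here, two have been measured in an assay on CHO cells for displacement of a labelled ligand from Alpha-2B adrenergic receptor (Homo sapiens); a lower number here means a stronger inhibitor, a higher number a weaker inhibitor. Within the data shown here, compound 1 `Cc1ccc(-c2ccccc2OC(C)C2=NCCN2)cc1` gives 398 nM, and compound 2 `Cc1ccccc1-c1ccccc1OC(C)C1=NCCN1` gives 832 nM, the higher of the two numbers; the only measured step, a 2.1-fold higher number from compound 1 to compound 2 (0.32 log units; beyond the scatter), separates them. Compound 3 `CC(Oc1ccccc1-c1ccccn1)C1=NCCN1` has not yet been measured. It differs from compound 2 by pyridin-2-yl in place of 2-methylphenyl on an aromatic carbon. Among the measured compounds shown here, the step from compound 1 to compound 2 is the only one touching this ring, and it was modest. For the measured compounds named here, no measured compound carries a pyridin-2-yl group, so the direction of the new step is not anchored by data. Compound 3 is therefore expected to sit near compound 2, with a step of a 1.1-fold higher number from compound 2 to compound 3 (0.03 log units; within the scatter) assumed, and an estimate of 900 nM, within 250 nM to 3500 nM.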

Compound 3, inhibition constant: 3310 nM
The estimate for compound 3 lay 3.7-fold (0.57 log units) below the measured number; measured number inside the range.
By their numbers in this assay, from the lowest: compound 1; then compound 2; then compound 3.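

In this assay, the new result shows that this position on the aromatic ring tolerates more than a shift of the methyl group can reveal: pyridin-2-yl, the only ring here with a hetero atom, gives the weakest binder of the three. The change costs affinity against both methylphenyl compounds, with a 4.0-fold higher number from compound 2 to compound 3 (0.60 log units; beyond the scatter) and, against the 4-methylphenyl compound, an 8.3-fold higher number from compound 1 to compound 3 (0.92 log units; beyond the scatter) in the same direction. No measurement on hand explains this loss.

The compounds shown cannot separate the effect of the ring nitrogen from that of losing the methyl group, since each carbon-only ring here carries a methyl and the pyridine ring does not. A plain phenyl group at this place would address that, and pyridin-3-yl or pyridin-4-yl would show whether the location of the nitrogen matters.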